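The source may report more compounds than this note shows. Statements on the series, on what has been measured and on what is new or still open speak of the compounds shown alone.

Of the compounds shown here, three sharing one core have been tested in a functional assay on SK-MEL-5 cells (Homo sapiens) for inhibition, read by sulforhodamine B assay, with a stated time of 48 h, tested at 10 uM; a higher number here means more inhibition at the concentration tested (going by the name of the read-out), a lower number less inhibition. Compound 1 `Fc1ccc(-c2cn3ccnc3c(-c3ccc4ncn(C5CCCCC5)c4c3)n2)cc1` gives 7.36% in this assay, compound 2 `c1cn2cc(-c3ccsc3)nc(-c3ccc4ncn(C5CCCCC5)c4c3)c2n1` gives 25%, and compound 3 `CC(=O)c1ccc(-c2cn3ccnc3c(-c3ccc4ncn(C5CCCCC5)c4c3)n2)cc1` gives 24.8%. Compound 3 thus stands second highest of the three numbers; its gap to compound 2 lies within the scatter, while its gap to compound 1 lies beyond it, as the step of a number 17.4 percentage points higher from compound 1 to compound 3 (beyond the scatter) shows. Compound 4 `COc1ccccc1-c1cn2ccnc2c(-c2ccc3ncn(C4CCCCC4)c3c2)n1` differs from compound 3 in one place: 2-methoxyphenyl in place of 4-acetylphenyl on an aromatic carbon. Within the data shown here, no measured step brings in a 2-methoxyphenyl, so the bearing of the data is indirect. The step of a number 0.2 percentage points lower from compound 2 to compound 3 (within the scatter) shows that exchanging one ring for another at this place can leave the number unchanged, whereas the step of a number 17.4 percentage points higher from compound 1 to compound 3 (beyond the scatter) shows a modest rise when acetyl replaces fluoro. A 2-methoxyphenyl is a further untested ring, so a small drop, within or near the scatter, is expected for the step of a number 6.8 percentage points lower from compound 3 to compound 4 (within the scatter). Compound 4 is therefore estimated at 18%, with a range from 5% to 35%.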

Compound 4, a percentage reported as inhibition, at one concentration (the size of the read-out at that concentration, not a potency): 8.94%
For compound 4 the middle estimate is 9.1 percentage points above the measured one; measured number inside the range.
By their numbers in this assay, from the lowest: compounds 1 and 4 (each within the scatter of the next); then compounds 3 and 2 (each within the scatter of the next).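

Exchanging one ring for another at this place need not leave the number unchanged: 2-methoxyphenyl gives a number 15.9 percentage points lower from compound 3 to compound 4 (beyond the scatter) and also a number 16.1 percentage points lower from compound 2 to compound 4 (beyond the scatter) in this assay. Yet it gives a number 1.6 percentage points higher from compound 1 to compound 4 (within the scatter), so the four compounds fall into two groups, with 4-fluorophenyl and 2-methoxyphenyl together and thiophen-3-yl and 4-acetylphenyl together. No measured property of these groups explains this division.

Going by these compounds, all four groups at this place are aromatic rings, and none of the four numbers is high, so it remains open whether any group here could give strong inhibition at the concentration tested. An amine or a carboxylic acid on the ring, or a longer chain in place of the ring, would test this.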